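This account rests on a few compounds, and the source may have more. Where it says the series, first, only, none or still open, it means among the compounds named here.

Three compounds have been measured in a functional assay on MDA-MB-231 cells (Homo sapiens) for inhibition, read by MTT assay, with a stated time of 72 h; a higher number here means a weaker inhibitor, a lower number a stronger inhibitor:

compound 1 `CNC(=O)CCCCCCCn1nc(-c2cnc3[nH]ccc3c2)c2c(N)ncnc21`: 15800 nM
compound 2 `Nc1ncnc2c1c(-c1cnc3[nH]ccc3c1)nn2CC(=O)NO`: > 150000 nM
compound 3 `Nc1ncnc2c1c(-c1cnc3[nH]ccc3c1)nn2CCCCCCCCC(=O)NO`: 11000 nM

The value of compound 2 is a limit of the assay (the limit of > 150000 nM in this assay, at which 1 of the 3 values shown sits). Compound 3 stands level with compound 1, since the step of a 1.4-fold lower number from compound 1 to compound 3 (0.16 log units; within the scatter) lies within the scatter. Compound 4 `Nc1ncnc2c1c(-c1cnc3[nH]ccc3c1)nn2CCCCC(=O)NO` has hydroxycarbamoyl in place of 4-(hydroxycarbamoyl)butyl on a saturated chain carbon, four bonds along the chain from an aromatic nitrogen. Its chain is shorter than that of compound 3 and longer than that of compound 2. The closest guide is the step of an at least 9.4-fold higher number from compound 1 to compound 2 (0.97 log units; beyond the scatter), which shows that the shortest chain costs much activity. A moderate rise toward a higher number is therefore expected, smaller than that step. The estimated step is a 3.6-fold higher number from compound 3 to compound 4 (0.56 log units; beyond the scatter). For compound 4 the expected value is 40000 nM, with an estimated range of 14000 nM to 120000 nM.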

Compound 4, half-maximal inhibitory concentration: > 50000 nM
Compound 4 gave a limit, no number; the forecaster's own chance of this, stated with the estimate: 15%; middle value at least 1.2-fold (0.09 log units) away from the limit.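

Compound 4 gave a limit of the assay, not a number: the limit of > 50000 nM in this assay, at which 1 of the 4 values shown sits.

Even so, the loss of activity is not confined to the shortest chain: hydroxycarbamoyl in place of 4-(hydroxycarbamoyl)butyl gives an at least 4.5-fold higher number from compound 3 to compound 4 (0.65 log units; beyond the scatter). Compound 4 also trails the methylamide, with an at least 3.1-fold higher number from compound 1 to compound 4 (0.50 log units; beyond the scatter).

The step between the two limits, compound 2 and compound 4, cannot be read, so the shorter chains remain unordered. Open too, from the compounds shown here alone, is whether a chain between those of compound 3 and compound 4, or a longer chain, or a carboxylic acid in place of hydroxycarbamoyl, would lower the number.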